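Aryl group change from compound 2 to compound 3

The source may hold more compounds than are shown below. What is called first, only, known or untested is meant among the compounds shown, and "the series" means these compounds.

Measured in a physicochemical assay for lipophilicity, read by HPLC, at pH 7.5; on this read-out lower numbers stand for lower lipophilicity and higher numbers for higher lipophilicity:
- compound 1 `CC[C@@H](Nc1c(C#N)c(-c2ccc(-c3ncccc3C)cc2)nc2cnccc12)C(N)=O`: 2
- compound 2 `CC[C@@H](Nc1c(C#N)c(-c2ccc(-c3cccc(Cl)c3OC)cc2)nc2cnccc12)C(N)=O`: 3.1

Compound 2, at 3.1, holds the higher of the two numbers in this assay. Within the data shown here, the only measured step, a number 1.10 log units higher from compound 1 to compound 2 (beyond the scatter), is large and beyond the scatter. It came with 3-chloro-2-methoxyphenyl in place of 3-methylpyridin-2-yl on an aromatic carbon.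

The next compound is compound 3 `CC[C@@H](Nc1c(C#N)c(-c2ccc(-c3ccc(F)cc3)cc2)nc2cnccc12)C(N)=O`, and its difference from compound 2 is 4-fluorophenyl in place of 3-chloro-2-methoxyphenyl on an aromatic carbon. In words, this is 4-fluorophenyl in place of 3-chloro-2-methoxyphenyl on an aromatic carbon, para to a large group.

The measured step bears on this change only in part: the same 3-chloro-2-methoxyphenyl is involved, but there it enters, and here it leaves. Among the measured compounds shown here, no measured step covers 4-fluorophenyl, so the size guide is weak. Both groups hold one six-membered aromatic ring of carbon only, whereas the entering group is the smaller.

The expected change is a number 0.40 log units lower from compound 2 to compound 3 (beyond the scatter) in this assay, a modest fall and well short of the measured step. For compound 3 the estimated value is 2.7, with an expected range of 2.3 to 3.1.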

Compound 3, distribution coefficient: 2.7
Compound 3: the middle estimate sits on the measured number at the digits printed; the range from low to high includes it.
By their numbers in this assay, from the lowest: compound 1; then compound 3; then compound 2.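

In this assay, the aromatic carbon para to a large group now has a third group to compare, and 4-fluorophenyl in place of 3-chloro-2-methoxyphenyl gives a number 0.40 log units lower from compound 2 to compound 3 (beyond the scatter), while 4-fluorophenyl in place of 3-methylpyridin-2-yl gives a number 0.70 log units higher from compound 1 to compound 3 (beyond the scatter). Among these compounds, the two groups with a six-membered aromatic ring of carbon only, in compound 2 and compound 3, both give higher numbers than the group in compound 1, with no compound shown going against this, and the smaller of the two, in compound 3, gives the lower number of that pair. Nothing available explains either step, so the shifts stand as observations only.

Going by these compounds, the change from compound 2 to compound 3 alters the ring's substituents together, so the separate contributions of the chlorine, the methoxy group and the fluorine remain open, and plain phenyl, 3-chlorophenyl or 2-methoxyphenyl at this position would be needed to separate them. On these data alone, it also remains open how far the number would fall with an aminomethyl or carboxylic acid group on this ring.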